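The compounds below may be only part of what the source reports. "The series", "measured", "known", "first", "only" and "open" are said of these compounds alone.

Compound 1 `CCCCCC(O)CN` and compound 3 `CCCCCC(C)(O)CN` share a core, and in an assay on isolated protein for inhibition of Phenylethanolamine N-methyltransferase (Bos taurus) (on this read-out higher numbers stand for weaker inhibition and lower numbers for stronger inhibition), compound 1 gives 314000 nM while compound 3 gives 669000 nM. The change between them is methyl in place of hydrogen on a saturated chain carbon bound to an oxygen on a saturated carbon and two saturated chain carbons, and it made a 2.1-fold higher number from compound 1 to compound 3 (0.33 log units; beyond the scatter). Compound 2 `CCCCCC(C)(C#N)O[Si](C)(C)C` stands on a different core; how the two cores differ is not broken down here. In this assay compound 2 gives 669000 nM, level with compound 3 at the digits reported and within the usual scatter of it. Compound 4 `CCCCCCC(C)(C#N)O[Si](C)(C)C` has not yet been measured. It differs from compound 2 by methyl in place of hydrogen on a saturated chain carbon, six bonds along the chain from an oxygen on an unsaturated carbon and a triple-bonded carbon, the same kind of change as that from compound 1 to compound 3, though the place is not the same: in compound 3 the methyl sits bound to an oxygen on a saturated carbon and two saturated chain carbons, whereas in compound 4 it sits six bonds along the chain from an oxygen on an unsaturated carbon and a triple-bonded carbon. Because compound 1 to compound 3 gave a 2.1-fold higher number from compound 1 to compound 3 (0.33 log units; beyond the scatter), the step from compound 2 to compound 4 is expected to be about a 1.2-fold higher number from compound 2 to compound 4 (0.08 log units; within the scatter), resting on that single earlier instance. Compound 4 is therefore estimated at 800000 nM in this assay, with a range from 300000 nM to 2000000 nM.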

Compound 4, half-maximal inhibitory concentration: 664000 nM
Compound 4: middle estimate off by 1.2-fold (0.08 log units), on the high side, within the range that was stated.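

In this assay, methyl in place of hydrogen on a saturated chain carbon, six bonds along the chain from an oxygen on an unsaturated carbon and a triple-bonded carbon, gave a 1.0-fold lower number from compound 2 to compound 4 (0.00 log units; within the scatter), so the two stand level. Set beside the earlier step, the two cores give no sign that this change behaves differently from one to the other: the same change on two cores in this assay, a 2.1-fold higher number (0.33 log units; beyond the scatter) from compound 1 to compound 3 and a 1.0-fold lower number (0.00 log units; within the scatter) from compound 2 to compound 4, 2.1-fold (0.33 log units) apart, within the scatter of two such steps. Among the compounds shown here, that does not show that the change carries reliably from core to core: each core offers only one pair, the methyl sits in a different place in each, and only the step on the core of compound 1 lies beyond the scatter.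

The compounds shown leave open whether a longer chain on the core of compound 2 would move the number in this assay at all. They also leave open how that core would read with a carboxylic acid in place of the nitrile.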